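This account rests on a few compounds, and the source may have more. Where it says the series, first, only, none or still open, it means among the compounds named here.

Measured so far:
compound 1 `CCc1ccc(N(CC(C)C)S(=O)(=O)c2ccc3cc(OCC4CCOCC4)c(CO)cc3c2)cc1` with 5.1 in a physicochemical assay for lipophilicity, at pH 7.4; on this read-out lower numbers stand for lower lipophilicity and higher numbers for higher lipophilicity;
compound 2 `Cc1ccc(NS(=O)(=O)c2ccc3c(c2)C(=O)CC(C2CCOCC2)O3)c(C)c1` with 2.75;
compound 3 `CCc1ccc(NS(=O)(=O)c2ccc3c(c2)C(=O)CC(C2CCOCC2)O3)cc1` with 2.67.

Among these three, compound 2 stands second highest; its nearest neighbour is compound 3, and the only single-point step here, a number 0.08 log units lower from compound 2 to compound 3 (within the scatter), lies within the scatter. For the measured compounds named here, compound 1 gives 5.1, a number far from that of compound 2 and beyond the scatter, but it differs from compound 2 in more than one place, so no single step connects them.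

Compound 4 `Cc1ccc(N(C2CCC2)S(=O)(=O)c2ccc3c(c2)C(=O)CC(C2CCOCC2)O3)c(C)c1` is not yet measured. It differs from compound 2 in one place: cyclobutyl in place of hydrogen on a sulfonamide nitrogen. Going by the values given here, no measured step here changes a substituent on the sulfonamide nitrogen, so the step from compound 2 to compound 3 gives no direct guide; it only shows that the shared core is otherwise similar between these two. Among the compounds with values here, what can be said is that compound 1, the one measured compound carrying a group on that nitrogen, gives 5.1.

On this basis the change is expected to raise this assay by a number 1.40 log units higher from compound 2 to compound 4 (beyond the scatter). Compound 4 is therefore estimated at 4.15, with a range from 3.6 to 4.7.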

Compound 4, distribution coefficient: 3.86
Compound 4: the middle estimate sits 0.29 log units above what was measured; measured number inside the range.
By their numbers in this assay, from the lowest: compounds 3 and 2 (each within the scatter of the next); then compound 4; then compound 1.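

For the compounds shown here, the one earlier step, 4-ethylphenyl in place of 2,4-dimethylphenyl on a sulfonamide nitrogen, came to a number 0.08 log units lower from compound 2 to compound 3 (within the scatter) in this assay and left that nitrogen still carrying its hydrogen. Replacing the hydrogen itself with cyclobutyl gives a number 1.11 log units higher from compound 2 to compound 4 (beyond the scatter) on the same read-out, the first direct sign that a single change at this nitrogen can move the number beyond the scatter. No measurement shown accounts for the size of this step.

From the compounds shown here alone, one substituent cannot show whether the step depends on the ring or simply on the loss of the hydrogen and the entry of carbon atoms, so methyl and cyclopropyl on this nitrogen remain open. Also open, going by these compounds, is how a chain ending in an amine or a carboxylic acid would read at the same place.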